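Chloro on the pyridine ring of vinyl sulfone activators

The source may report more compounds than this note shows. Statements on the series, on what has been measured and on what is new or still open speak of the compounds shown alone.

Measured so far:
compound 1, `O=S(=O)(/C=C/c1ccccn1)c1ccc(F)cc1`, 3100 nM
compound 2, `O=S(=O)(/C=C/c1ccc(Cl)cn1)c1ccc(F)cc1`, 4370 nM
compound 3, `O=S(=O)(/C=C/c1cccnc1)c1ccccc1F`, 6860 nM

These three compounds were tested in an assay on U2OS cells for activation of nuclear factor erythroid 2-related factor 2 (Homo sapiens), read by beta-arrestin recruitment, with a stated time of 6 h; a lower number here means that less compound is needed, a higher number that more compound is needed for the effect. Compound 1 gives 3100 nM, compound 2 gives 4370 nM, and compound 3 gives 6860 nM, the highest number of the three.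

Compound 1 and compound 2 differ in one place: chloro in place of hydrogen on an aromatic carbon. This change made a 1.4-fold higher number from compound 1 to compound 2 (0.15 log units; within the scatter). Compound 3 has the same atoms as compound 1, joined differently; the difference between the two cores is not broken down here.

Compound 4, `O=S(=O)(/C=C/c1ccc(Cl)nc1)c1ccccc1F`, has not yet been measured in this assay . It is made from compound 3 by the same kind of change: chloro in place of hydrogen on an aromatic carbon. The place is not identical, since in compound 2 the chloro sits two atoms from the ring nitrogen, whereas in compound 4 it sits next to the ring nitrogen.

Resting on the step from compound 1 to compound 2 in this assay , compound 4 is expected to show roughly a 1.3-fold higher number from compound 3 to compound 4 (0.12 log units; within the scatter), that is, a number near that of compound 3. The estimate for compound 4 in this assay is 9000 nM, with a likely range from 4000 nM to 20000 nM.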

Compound 4, half-maximal effective concentration: 2550 nM
Beside the measured number, compound 4's estimate is 3.5-fold (0.55 log units) above it; measured number outside the range, below it.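

In this assay, chloro in place of hydrogen on an aromatic carbon gave a 2.7-fold lower number from compound 3 to compound 4 (0.43 log units; beyond the scatter), so this time the number fell by more than the usual scatter. The same kind of change therefore did not carry over from one core to the other in this small set: the same change on two cores in this assay, a 1.4-fold higher number (0.15 log units; within the scatter) from compound 1 to compound 2 and a 2.7-fold lower number (0.43 log units; beyond the scatter) from compound 3 to compound 4, 3.8-fold (0.58 log units) apart, beyond the scatter of two such steps. This does not show why the two steps differ, since the cores differ and the chloro also sits in a different place, next to the ring nitrogen only in compound 4, and one pair on each core cannot separate these two differences or support a general rule for the series.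

The compounds shown leave open how chloro next to the ring nitrogen would behave on the core of compound 1, a comparison that would help to separate the effect of the core from that of the place. They also leave open whether another group at that place, such as methyl, an amine or a nitrile, would give a step like that of chloro.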